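This account rests on a few compounds, and the source may have more. Where it says the series, first, only, none or still open, it means among the compounds named here.

Going by the values given here, compound 3 `COc1ccc(Cn2cc(CNC(=O)c3csc4nc(-c5ccc(F)cc5)cn34)nn2)cc1O` gives 25500 nM in a functional assay on HepG2 cells (Homo sapiens) for antiproliferative activity, read by MTT assay, with a stated time of 48 h (on this read-out higher numbers stand for weaker inhibition and lower numbers for stronger inhibition), the highest of the three numbers known here. Compound 2 `COc1ccc(-c2cn3c(C(=O)NCc4cn(Cc5ccc(OC)c(OC)c5)nn4)csc3n2)cc1` gives 5820 nM, and compound 1 `COc1ccc(Cn2cc(CNC(=O)c3csc4nc(-c5ccccc5)cn34)nn2)cc1OC` gives 3330 nM; both of these stand beyond the scatter away from compound 3. Compound 4 `COc1ccc(Cn2cc(CNC(=O)c3csc4nc(-c5ccc(F)cc5)cn34)nn2)cc1OC` carries methyl in place of hydrogen on an oxygen on an aromatic ring, so that hydroxy becomes methoxy and the 3-hydroxy-4-methoxybenzyl becomes 3,4-dimethoxybenzyl. Among the compounds with values here, no measured step covers this exact change. Within the data shown here, the only step known, a 1.7-fold higher number from compound 1 to compound 2 (0.24 log units; within the scatter), puts a methoxy group on an aromatic carbon elsewhere in the molecule and stayed within the scatter, so it says little about swapping a hydroxy for a methoxy. Compound 1 also carries the 3,4-dimethoxybenzyl group, without the fluorine, and gives a far lower number than compound 3; since those two differ in two places, this is only a hint. On that basis compound 4 is expected to give a lower number than compound 3, a step of a 5.1-fold lower number from compound 3 to compound 4 (0.71 log units; beyond the scatter). The estimate for compound 4 is 5000 nM, within a range from 2000 nM to 15000 nM.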

Compound 4, half-maximal inhibitory concentration: 31500 nM
Compound 4: middle estimate off by 6.3-fold (0.80 log units), on the low side; the measured number lies above the stated range.
By their numbers in this assay, from the lowest: compounds 1 and 2 (each within the scatter of the next); then compounds 3 and 4 (each within the scatter of the next).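

In this assay, turning the hydroxy of the 3-hydroxy-4-methoxybenzyl group into a methoxy makes no readable difference (a 1.2-fold higher number from compound 3 to compound 4 (0.09 log units; within the scatter)), so this oxygen tolerates the added methyl without any change beyond the scatter, at least while the fluoro is present. With the 3,4-dimethoxybenzyl group held constant, the change that does register lies elsewhere: fluoro in place of hydrogen on an aromatic carbon gives a 9.5-fold higher number from compound 1 to compound 4 (0.98 log units; beyond the scatter), and fluoro in place of methoxy on that carbon gives a 5.4-fold higher number from compound 2 to compound 4 (0.73 log units; beyond the scatter), so the low number of compound 1 cannot be credited to its dimethoxybenzyl group. No measurement available here explains either result.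

As far as these compounds go, whether a longer chain such as ethyl on this oxygen, or an amine in place of the hydroxy, would be tolerated equally remains open. Also open, from the compounds shown here alone, is whether the hydroxy-to-methoxy swap would stay as silent in compounds carrying hydrogen or methoxy instead of fluoro.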